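The source may report more compounds than this note shows. Statements on the series, on what has been measured and on what is new or still open speak of the compounds shown alone.

Compound 1 `COc1cc(-c2nccn3cc(-c4ccc([N+](=O)[O-])cc4)nc23)cc(OC)c1OC` gives > 10000 nM in a functional assay on HepG2 cells (Homo sapiens) for inhibition, read by MTT assay, with a stated time of 48 h (on this read-out lower numbers stand for stronger inhibition and higher numbers for weaker inhibition), which is a limit of the assay and not a number. Within the data shown here, compound 2 `COc1cc(-c2nccn3cc(-c4ccc(N)cc4)nc23)cc(OC)c1OC` gives 252 nM in this assay, the only true number so far. Next is compound 3 `COc1cc(-c2nccn3cc(-c4ccc(O)cc4)nc23)cc(OC)c1OC`: hydroxy in place of amino on an aromatic carbon. Among the measured compounds shown here, one measured step bears on this, the large at least 39-fold lower number from compound 1 to compound 2 (1.59 log units; beyond the scatter), where amino replaced nitro. A smaller step towards a higher number is expected in this assay, and the expected size is a 2.4-fold higher number from compound 2 to compound 3 (0.38 log units; beyond the scatter). For compound 3 the estimated value is 600 nM, with an expected range of 120 nM to 4000 nM.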

Compound 3, half-maximal inhibitory concentration: 823 nM
Compound 3: the middle estimate sits 1.4-fold (0.14 log units) below what was measured; measured number inside the range.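

Hydroxy in place of amino on this aromatic carbon costs only a modest step in this assay, a 3.3-fold higher number from compound 2 to compound 3 (0.51 log units; beyond the scatter), so the amino group is not the only group here that gives a measurable value. Hydroxy in place of nitro gives an at least 12-fold lower number from compound 1 to compound 3 (1.08 log units; beyond the scatter), so the large drop seen with amino also appears with a second group. The value of compound 1 is a limit, not a number: the limit of > 10000 nM in this assay, at which 1 of the 3 values shown sits.

On these data alone, how a methylamino group, an acetamido group or a carboxylic acid would read at this place stays open. So does whether amino still ranks ahead of hydroxy when the rest of the core changes.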